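The compounds below may be only part of what the source reports. "The series", "measured", "known", "first", "only" and "open" are said of these compounds alone.

In a functional assay on MDA-MB-231 cells (Homo sapiens) for inhibition, read by MTT assay, with a stated time of 72 h (on this read-out higher numbers stand for weaker inhibition and lower numbers for stronger inhibition), compound 1 `C=CC(=O)Nc1cccc(NC(=O)CSc2nc(Nc3ccccc3F)c3ccccc3n2)c1` gives 18700 nM, compound 2 `C=CC(=O)Nc1cccc(NC(=O)CSc2nc(Nc3cccc(C)c3)c3ccccc3n2)c1` gives 16800 nM, and compound 3 `C=CC(=O)Nc1cccc(NC(=O)CSc2nc(Nc3cccc(OC)c3)c3ccccc3n2)c1` gives 12900 nM. Among these three numbers compound 3 holds the lowest, yet the distances to its neighbours are small: a 1.3-fold lower number from compound 2 to compound 3 (0.11 log units; within the scatter) and a 1.4-fold lower number from compound 1 to compound 3 (0.16 log units; within the scatter), both within the scatter. For the measured compounds named here, every step so far has swapped the substituted phenyl ring sitting on the nitrogen on an aromatic ring, and none of them moved the read-out beyond the scatter: a 1.1-fold lower number from compound 1 to compound 2 (0.05 log units; within the scatter) alongside the two steps just named.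

Compound 4 `C=CC(=O)Nc1cccc(NC(=O)CSc2nc(Nc3ccc(Br)cc3)c3ccccc3n2)c1` has not yet been measured. It differs from compound 3 in one place: 4-bromophenyl in place of 3-methoxyphenyl on a nitrogen on an aromatic ring. The earlier exchanges at this same nitrogen, between a 2-fluorophenyl, a 3-methylphenyl and a 3-methoxyphenyl, all stayed within the scatter, and the 4-bromophenyl is simply a fourth ring placed there. Going by the values given here, no measured step points to a large movement in either direction, so the number for compound 4 is expected to stay close to that of compound 3. For compound 4 the estimate in this assay is 14000 nM, with a range from 6000 nM to 35000 nM, which amounts to an expected step of a 1.1-fold higher number from compound 3 to compound 4 (0.04 log units; within the scatter).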

Compound 4, half-maximal inhibitory concentration: 17300 nM
Estimate against measurement, compound 4: 1.2-fold (0.09 log units) below, within the range that was stated.
By their numbers in this assay, from the lowest: compounds 3, 2, 4 and 1 (each within the scatter of the next).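

In this assay, the 4-bromophenyl on this nitrogen behaves like the three rings already tried, with all three new steps within the scatter: a 1.3-fold higher number from compound 3 to compound 4 (0.13 log units; within the scatter), a 1.0-fold higher number from compound 2 to compound 4 (0.01 log units; within the scatter) and a 1.1-fold lower number from compound 1 to compound 4 (0.03 log units; within the scatter). The position has now taken four different substituted phenyl rings, and this change, which removes the oxygen of the methoxy and brings in a bromine, still leaves the read-out within the scatter, so for these four compounds the choice of ring on this nitrogen makes no readable difference. No accompanying measurement offers an explanation for this flat result.

All four compounds keep a substituted phenyl ring on this nitrogen, so they leave open whether the read-out would hold for a ring carrying a carboxylic acid or an amine, or for a longer chain in place of the ring. Everything else in the molecule is the same across the four, so they also cannot tell whether a change elsewhere in the shared core would move the number further than the changes at this nitrogen have.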